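A few compounds are considered here, and "the series" means these few. Any claim that something is new, unique, unknown or untested is made for them only; others in the source may bear on it.

Measured so far in a functional assay on A-375 cells (Homo sapiens) for antiproliferative activity, read by MTT assay, with a stated time of 48 h, in the presence of a further agent that is not named here; on this read-out higher numbers stand for weaker inhibition and lower numbers for stronger inhibition:
- compound 1, `O=C(Nc1ccc(-n2ccc3c(NC(=O)c4ccccc4)nccc32)cc1)Nc1cccc(Cl)c1Cl`: in this assay compound 1 gives > 10000 nM, a limit of the assay rather than a number
- compound 2, `O=C(Nc1ccc(-n2ccc3c(NC(=O)c4ccccc4)nccc32)cc1)Nc1cc(C(F)(F)F)cc(C(F)(F)F)c1`: in this assay compound 2 gives 1800 nM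
- compound 3, `Cc1cc(NC(=O)Nc2cccc(Cl)c2Cl)ccc1-n1ccc2c(NC(=O)c3ccccc3)nccc21`: in this assay compound 3 gives > 10000 nM, again a limit and not a number

Compound 1 therefore stands at the limit, with nothing more known than that; this holds for two of the three values, as the evidence on the limit states (the limit of > 10000 nM in this assay, at which 2 of the 3 values shown sit). Among the measured compounds shown here, the one readable number in the set belongs to compound 2, whose urea carries a bis(trifluoromethyl)phenyl group. For the measured compounds named here, the only one-place step measured, a step that the two limits leave unreadable from compound 1 to compound 3, is unreadable, so no direction can be taken from it.

The step to compound 4, `O=C(Nc1ccc(-n2ccc3c(NC(=O)c4ccccc4)nccc32)cc1)c1cccc(C(F)(F)F)c1`, is 3-(trifluoromethyl)phenyl in place of (2,3-dichlorophenyl)amino on a carbonyl carbon. Going by the values given here, no measured step touches this change, and the limit of compound 1 gives no starting number; the expectation for compound 4 can only be set near the limit, with a wide range. The step from compound 1 to compound 4 is expected to be an at least 1.2-fold lower number from compound 1 to compound 4 (0.09 log units; that floor lies within the scatter). Compound 4 is estimated at 8000 nM, within 2000 nM to 30000 nM.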

Compound 4, half-maximal inhibitory concentration: 100 nM
Estimate against measurement, compound 4: 80-fold (1.90 log units) above; the whole stated range lies above it.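

In this assay, the carbonyl carbon proves to be a position where a single change moves the read-out, with 3-(trifluoromethyl)phenyl in place of (2,3-dichlorophenyl)amino giving an at least 100-fold lower number from compound 1 to compound 4 (2.00 log units; beyond the scatter). The change removes the hydrogen-bond donor of the leaving group and alters the ring substitution at once, so this one step does not separate the two. Compound 1 is a limit of the assay, so the size of the step is only a floor: the limit of > 10000 nM in this assay, at which 2 of the 4 values shown sit.

Open, from the compounds shown here alone, is how other groups on this carbonyl carbon, such as a morpholine, a carboxylic acid or a longer alkyl chain, would read. Also open, going by these compounds, is whether (3-(trifluoromethyl)phenyl)amino on the same carbon, which keeps the new ring and restores the nitrogen, would separate the two parts of the change.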